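The source may hold more compounds than are shown below. What is called first, only, known or untested is meant among the compounds shown, and "the series" means these compounds.

Measured compounds:

Compound 1, `ClCc1ccc(Cn2cnc3c(Cl)ncnc32)cc1`: 3160 nM in a functional assay on IGROV-1 cells (Homo sapiens) for cytotoxicity, read by sulforhodamine B assay, with a stated time of 48 h; a higher number here means a weaker inhibitor of growth, a lower number a stronger inhibitor of growth
Compound 2, `ClCc1ccccc1Cn1cnc2c(Cl)ncnc21`: 3160 nM
Compound 3, `ClCc1ccc(Cn2cnc3nc(Cl)nc(Cl)c32)cc1`: 1410 nM

All three numbers come from the same test, which reports the concentration at which growth of the cells is inhibited to the stated degree. Compound 1 gives 3160 nM, and compound 2 gives 3160 nM; these two are level at the digits shown and sit together at the high end of the set, so neither can be called weaker or stronger than the other. Compound 3 gives 1410 nM, a lower number that lies beyond the usual scatter, so it is the stronger growth inhibitor of the three.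

Compound 4, `ClCc1ccc(Cn2cnc3c(Cl)nc(Cl)nc32)cc1`, has not yet been measured in this assay. It differs from compound 1 in one place: chloro in place of hydrogen on an aromatic carbon. Compound 3 also bears two chloro groups on the shared core, and compound 3 gives 1410 nM. On that basis a small move toward a lower number is expected, a 1.8-fold lower number from compound 1 to compound 4 (0.24 log units; within the scatter), though it may well fall within the scatter. Compound 4 is therefore expected to give about 1800 nM, within a range from 700 nM to 4500 nM.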

Compound 4, concentration for 50% growth inhibition: 15100 nM
Compound 4: middle estimate off by 8.4-fold (0.92 log units), on the low side, outside the stated range (above it).
By their numbers in this assay, from the lowest: compound 3; then compounds 1 and 2 (each within the scatter of the next); then compound 4.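

In this assay chloro in place of hydrogen on the aromatic carbon between two ring nitrogen atoms gives a 4.8-fold higher number from compound 1 to compound 4 (0.68 log units; beyond the scatter) and this step lies beyond the usual scatter, so here the added chlorine goes with weaker growth inhibition. Within the data shown here, this is the first single change that can be read in the set, since none of the earlier compounds differ from one another in just one place. Nothing available explains this loss of growth inhibition.

Whether the loss belongs to chloro itself or would follow any group on this carbon stays open, as only hydrogen and chloro are shown there; a methyl group, a methoxy group or an amine would help to separate the two. Also open, on these data alone, is whether the same change on compound 2 would give a step of similar size.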